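The compounds below may be only part of what the source reports. "The series", "measured", "known", "first", "only" and "open" are said of these compounds alone.

Of the compounds shown here, three sharing one core have been measured in a functional assay on the whole organism (Tail, strain ICR) with Mus musculus as the target, in the tail flick test, with a stated time of 90 min, at a dose of 25 umol/kg by the oral route; a lower number here means a weaker effect, a higher number a stronger effect of the compound at the dose given. Compound 1 `NCCCC[C@H](NC(=O)CN(c1nc(Cl)nc2[nH]cnc12)C1CC1)C(=O)OCc1ccccc1` gives 35.3% in this assay. Compound 2 `O=C(O)CC[C@H](NC(=O)CN(c1nc(Cl)nc2[nH]cnc12)C1CC1)C(=O)O` gives 44.7%, and compound 3 `CSCC[C@H](NC(=O)CN(c1nc(Cl)nc2[nH]cnc12)C1CC1)C(=O)O` gives 14%. Among these three numbers compound 1 stands second highest: its value and that of compound 2 lie within the scatter of each other, while compound 3 lies beyond the scatter below compound 1.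

Within the data shown here, only one single-point step is available, and it runs a number 30.7 percentage points lower from compound 2 to compound 3 (beyond the scatter), a change of methylsulfanyl in place of carboxy on a saturated chain carbon, three bonds along the chain from an amide-type nitrogen and a carbonyl carbon.

Compound 4 `NC(=O)CC[C@H](NC(=O)CN(c1nc(Cl)nc2[nH]cnc12)C1CC1)C(=O)OCc1ccccc1` has not yet been measured in this assay. It differs from compound 1 as follows: carbamoyl in place of 2-aminoethyl on a saturated chain carbon, three bonds along the chain from an amide-type nitrogen and a carbonyl carbon. Among the measured compounds shown here, this change sits at the same place in the chain as the measured step, but it exchanges different groups, so that step does not cover it directly; no other pair speaks to it. The account therefore expects no step beyond the scatter from compound 1 to compound 4, a number 1.7 percentage points higher from compound 1 to compound 4 (within the scatter). For compound 4 the estimated value in this assay is 37%, with a range from 20% to 55%.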

Compound 4, a percentage reported as activity, at one dose (the size of the read-out at that dose, not a potency): 42.8%
Compound 4: middle estimate off by 5.8 percentage points, on the low side; low and high end bracket the measured number.
By their numbers in this assay, from the lowest: compound 3; then compounds 1, 4 and 2 (each within the scatter of the next).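

In this assay, among these compounds, carbamoyl in place of 2-aminoethyl on a saturated chain carbon, three bonds along the chain from an amide-type nitrogen and a carbonyl carbon, gives a number 7.5 percentage points higher from compound 1 to compound 4 (within the scatter), so this is the first change at this place that produces no step beyond the scatter. The earlier step at the same place, a number 30.7 percentage points lower from compound 2 to compound 3 (beyond the scatter), had shown only that this position can carry a large difference; the new pair shows that not every exchange there does, since a 4-aminobutyl and a 2-carbamoylethyl side chain are not told apart by this read-out. No accompanying measurement bears on the reason for this result.

From the compounds shown here alone, the two steps also stand on different backgrounds, compound 2 and compound 3 carrying a free carboxylic acid where compound 1 and compound 4 carry a benzyl ester, so it remains open whether methylsulfanyl and carboxy would differ as widely on the ester background. Also open, going by these compounds, is how a guanidine, a hydroxyl or a longer alkyl chain at this place would read against the amine and the carbamoyl.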